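Adding a Nitro Group to the Phenyl Ring of Compound 1

A few compounds are considered here, and "the series" means these few. Any claim that something is new, unique, unknown or untested is made for them only; others in the source may bear on it.

Compound 1 `CCOC(=O)c1c(-c2ccccc2)[nH]c2cc(OC)ccc2c1=O` was tested in an ADME assay on BJ cells (Homo sapiens) for cytotoxicity, read by luminescence, with a stated time of 72 h; a higher number here means that more compound is needed for the effect, a lower number that less compound is needed. In this assay compound 1 gives only a limit, > 21500 nM, not a number. Compound 2 `CCOC(=O)c1c(-c2cccc(OCc3ccccc3)c2)[nH]c2cc(OC)ccc2c1=O` likewise shows only a limit of > 21500 nM. Compound 3 `CCOC(=O)c1c(-c2cccc(Cl)c2)[nH]c2cc(OC)ccc2c1=O` also stops at a limit of > 21500 nM. Because (the limit of > 21500 nM in this assay, at which 3 of the 3 values shown sit), the steps a step that the two limits leave unreadable from compound 1 to compound 2 and a step that the two limits leave unreadable from compound 1 to compound 3 cannot be given a size. Compound 4 `CCOC(=O)c1c(-c2cccc([N+](=O)[O-])c2)[nH]c2cc(OC)ccc2c1=O` differs from compound 1 in one place: nitro in place of hydrogen on an aromatic carbon. Among the measured compounds shown here, no measured step tells how large such a change is here; the two measured changes at the same position only show that neither one moved its compound off the limit. Compound 4 is therefore expected to stay at the limit too, with an estimated step that the limit leaves unreadable from compound 1 to compound 4. The estimated value for compound 4 is 30000 nM, ranging from 12000 nM to 100000 nM.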

Compound 4, half-maximal effective concentration: > 21500 nM
Compound 4 was reported as a limit; the forecaster's own chance of this, stated with the estimate: 85%; the middle value does not contradict the limit.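

Compound 4 gives no readable step against compound 1, compound 2 or compound 3, since all of them stop at one shared limit: the limit of > 21500 nM in this assay, at which 4 of the 4 values shown sit.

The compounds shown leave open what concentration, if any, would produce the effect in this assay.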